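The source may report more compounds than this note shows. Statements on the series, on what has been measured and on what is new or still open speak of the compounds shown alone.

The series rests on the shared core shown for compound 1 `COc1cc2c(c(O)c1C(C)=O)C(=O)CC(C)(C)O2`, which in an ADME assay on cells (Erythrocyte, Homo sapiens), read by spectrophotometry and hemolysis (a lower number here means a stronger inhibitor, a higher number a weaker inhibitor), gives 1.24 ug/mL. Compound 2 `COc1cc(O)c2c(c1C(C)=O)OC(C)(C)C=C2` gives 0.0182 ug/mL in this assay, and compound 3 `COc1c(Cl)c(OC)c2c(c1C(C)=O)OC(C)(C)C(OC)C2Cl` gives 0.222 ug/mL. Among the three numbers compound 3 holds the second highest place: its number lies below that of compound 1 and above that of compound 2, and both gaps lie beyond the usual scatter of this assay. Compound 4 `COc1c(Cl)c(O)c2c(c1C(C)=O)OC(C)(C)C(OC)C2Cl` has not yet been measured. It differs from compound 3 in one place: hydrogen in place of methyl on an oxygen on an aromatic ring. The two measured compounds that carry a hydroxy on an aromatic ring, compound 1 and compound 2, sit at opposite ends of the numbers, so the measured set gives no direction for this change. A step of modest size from compound 3 to compound 4 is expected in this assay, a 1.2-fold lower number from compound 3 to compound 4 (0.09 log units; within the scatter), with neither direction favoured. Compound 4 is expected to give about 0.18 ug/mL, within a range of 0.04 ug/mL to 0.8 ug/mL.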

Compound 4, half-maximal inhibitory concentration: 0.0102 ug/mL
The estimate for compound 4 lay 18-fold (1.25 log units) above the measured number; the whole stated range lies above it.
By their numbers in this assay, from the lowest: compounds 4 and 2 (each within the scatter of the next); then compound 3; then compound 1.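

In this assay, within the data shown here, the change from methoxy to hydroxy on this oxygen gives a 22-fold lower number from compound 3 to compound 4 (1.34 log units; beyond the scatter), the first direct reading of any single change. The earlier compounds shown here could not show this, since no two of them differed in one place, and their hydroxy-bearing members gave no direction. It shows that this position responds strongly to the loss of one methyl in this setting, although nothing shown accounts for the size of the step.

The compounds shown leave open whether an ethyl or a longer chain on this oxygen would behave like the methyl, and whether an amine in place of the hydroxy would retain the lower number. They also leave open whether the same change would give a similar step on the cores of compound 1 and compound 2.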